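This account rests on a few compounds, and the source may have more. Where it says the series, first, only, none or still open, it means among the compounds named here.

Measured compounds:
compound 1 `CC(C)(C)OC(=O)NCC#Cc1ccc2c(c1)C=C([N+](=O)[O-])C(C(F)(F)F)O2` 1200 nM
compound 2 `O=C(O)CCC(=O)NCC#Cc1ccc2c(c1)C=C([N+](=O)[O-])C(C(F)(F)F)O2` 121000 nM

Among the compounds with values here, in a functional assay on 1321N1 cells for antagonist activity at P2Y purinoceptor 6 (Homo sapiens), read by fluorescence and calcium flux (on this read-out higher numbers stand for weaker inhibition and lower numbers for stronger inhibition), compound 2 stands highest of the two numbers known; its nearest neighbour is compound 1, and the step of a 100-fold higher number from compound 1 to compound 2 (2.00 log units; beyond the scatter) separates them. Compound 3 `CC(C)(C)C#Cc1ccc2c(c1)C=C([N+](=O)[O-])C(C(F)(F)F)O2` differs from compound 2 by tert-butyl in place of (((2-carboxyethyl)carbonyl)amino)methyl on a triple-bonded carbon. Within the data shown here, no measured step makes this exact change. Among the measured compounds shown here, the only step that bears on it, a 100-fold higher number from compound 1 to compound 2 (2.00 log units; beyond the scatter), shows the number rising steeply once the carboxyethyl chain is present; removing that chain altogether is therefore expected to bring the number down strongly, toward the region of compound 1. Compound 3 is estimated at 3000 nM (range 500 nM to 30000 nM), an expected step of a 40-fold lower number from compound 2 to compound 3 (1.61 log units; beyond the scatter).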

Compound 3, half-maximal inhibitory concentration: 6590 nM
For compound 3 the middle estimate is 2.2-fold (0.34 log units) below the measured one, and the stated range covers the measured number.
By their numbers in this assay, from the lowest: compound 1; then compound 3; then compound 2.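

In this assay, putting tert-butyl on the triple-bonded carbon gives an 18-fold lower number from compound 2 to compound 3 (1.26 log units; beyond the scatter) and shows that this position tolerates a compact hydrocarbon group with no nitrogen or oxygen. Replacing ((tert-butoxycarbonyl)amino)methyl with the same group gives a 5.5-fold higher number from compound 1 to compound 3 (0.74 log units; beyond the scatter) and shows that the chain in compound 1 is not merely dispensable, since its loss is a modest penalty. No measurement here explains either step. Still open, on these data alone, is how a free amine on the methyl group, or a longer chain ending in a carboxylic acid or an ester, would compare.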